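A few compounds are considered here, and "the series" means these few. Any claim that something is new, unique, unknown or untested is made for them only; others in the source may bear on it.

Measured so far in an assay on isolated protein for displacement of a labelled ligand from melanin-concentrating hormone receptor 1 (Homo sapiens); on this read-out lower numbers stand for stronger inhibition and higher numbers for weaker inhibition:

Compound 1 `CC(C)N(C)c1ccc2cc(NC(=O)CCc3ccc(C(F)(F)F)cc3)ccc2n1` gives 2 nM.
Compound 2 `CC1CCCN1c1ccc2cc(NC(=O)CCc3ccc(C(F)(F)F)cc3)ccc2n1` gives 5 nM.
Compound 3 `CC(=O)NC1CCN(c2ccc3cc(NC(=O)CCc4ccc(C(F)(F)F)cc4)ccc3n2)C1` gives 5 nM.

Among the compounds with values here, compound 3 stands level with compound 2 and together they hold the highest numbers of the three; the step of a 2.5-fold higher number from compound 1 to compound 3 (0.40 log units; beyond the scatter) is the only one separating compound 3 from another compound beyond the scatter. Compound 4 `O=C(CCc1ccc(C(F)(F)F)cc1)Nc1ccc2nc(N3CCCCC3)ccc2c1` differs from compound 3 by piperidin-1-yl in place of 3-acetamidopyrrolidin-1-yl on an aromatic carbon. Within the data shown here, the steps that bear on this are a 2.5-fold higher number from compound 1 to compound 2 (0.40 log units; beyond the scatter) and a 2.5-fold higher number from compound 1 to compound 3 (0.40 log units; beyond the scatter), both modest and both moving from an acyclic amine to a cyclic one, while no change at the digits printed from compound 2 to compound 3 (within the scatter) shows that swapping one cyclic amine for another left the number unchanged. A cyclic amine again replaces a cyclic amine here, so no step beyond the scatter is expected: a 1.3-fold lower number from compound 3 to compound 4 (0.10 log units; within the scatter). Compound 4 is estimated at 4 nM, in the range 1.5 nM to 12 nM.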

Compound 4, half-maximal inhibitory concentration: 12 nM
Estimate against measurement, compound 4: 3.0-fold (0.48 log units) below; the range from low to high includes it.
By their numbers in this assay, from the lowest: compound 1; then compounds 2 and 3 (each within the scatter of the next); then compound 4.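

With a cyclic amine at this position, the ring is not freely interchangeable: a 2.4-fold higher number from compound 3 to compound 4 (0.38 log units; beyond the scatter) and a 2.4-fold higher number from compound 2 to compound 4 (0.38 log units; beyond the scatter) both lie beyond the scatter, although the two substituted pyrrolidines gave matching numbers. The acyclic isopropyl(methyl)amino group still holds the lowest number, and a 6.0-fold higher number from compound 1 to compound 4 (0.78 log units; beyond the scatter) is the widest gap in the series. Nothing at hand accounts for the piperidine result.

Still open, going by these compounds, is whether morpholin-4-yl or azetidin-1-yl would sit with the pyrrolidines or with piperidin-1-yl. Also open, on these data alone, is whether an acetamido group on the piperidine ring would bring the number back down.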